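This account rests on a few compounds, and the source may have more. Where it says the series, first, only, none or still open, it means among the compounds named here.

Compound 3 `O=C(NC(=S)N1CCc2c(OCCCCCOc3ccc(Cl)cc3)cccc21)c1ccoc1` was tested in an ADME assay on Huh-7 cells (Homo sapiens) for cytotoxicity (a higher number here means that more compound is tolerated, a lower number that less compound is tolerated), and gave 20100 nM. Compound 1 `O=C(NC(=S)N1CCc2c(OCCCCCOc3ccc(Cl)cc3)cccc21)Oc1ccccc1` reached only the limit of the measurement, > 50000 nM, in this assay. Compound 2 `O=C(NC(=S)N1CCc2c(OCCCCCOc3ccc(Cl)cc3)cccc21)c1ccco1` gave 4620 nM in this assay. Of the two numbers given, compound 3 stands highest, with compound 2 nearest, and the step of a 4.4-fold higher number from compound 2 to compound 3 (0.64 log units; beyond the scatter) is beyond the scatter. Compound 4 `O=S(=O)(NC(=S)N1CCc2c(OCCCCCOc3ccc(Cl)cc3)cccc21)c1ccccc1` is not yet measured; it differs from compound 3 in that (phenylsulfonyl in place of (furan-3-yl)carbonyl on an amide-type nitrogen). Within the data shown here, the steps of an at least 2.4-fold lower number from compound 1 to compound 3 (0.39 log units; beyond the scatter) and an at least 10-fold lower number from compound 1 to compound 2 (1.03 log units; beyond the scatter) show that exchanging the group on the carbonyl carbon moved this assay by modest to large amounts, but none of the measured steps introduces a phenylsulfonyl on the nitrogen, so the direction is uncertain. Compound 4 is expected to show a step of a 1.2-fold higher number from compound 3 to compound 4 (0.09 log units; within the scatter). For compound 4 a value of 25000 nM is estimated, with a range from 8000 nM to 80000 nM.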

Compound 4, half-maximal cytotoxic concentration: > 50000 nM
Compound 4 ended at the assay's limit (the forecaster's own chance of this, stated with the estimate: 30%); at least 2.0-fold (0.30 log units) between middle value and limit.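

Replacing the furan carbonyl groups with phenylsulfonyl on the amide-type nitrogen gives an at least 2.4-fold higher number from compound 3 to compound 4 (0.39 log units; beyond the scatter) and an at least 10-fold higher number from compound 2 to compound 4 (1.03 log units; beyond the scatter) in this assay. Compounds 1 to 3 vary only the group on a carbonyl carbon, whereas compound 4 shows that exchanging the carbonyl for a sulfonyl also moves this number upward. The step between compound 1 and compound 4 cannot be read, as both sit at a limit: the limit of > 50000 nM in this assay, at which 2 of the 4 values shown sit.

On these data alone, what a benzoyl or a methylsulfonyl group on this nitrogen would give remains open, so the parts played by the sulfonyl and the phenyl ring cannot be separated.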